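A few compounds are considered here, and "the series" means these few. Any claim that something is new, unique, unknown or untested is made for them only; others in the source may bear on it.

Compound 2 `COC(=O)C1=CC2=CC(=O)[C@@](C)(O)[C@@H](OC(=O)c3c(C)cc(O)cc3O)[C@@H]2CO1` stands at the edge of the measured range in an assay on isolated protein for inhibition of Alpha glucosidase (Homo sapiens), read by spectrophotometry, with stated times of 20 min and 1 min; on this read-out higher numbers stand for weaker inhibition and lower numbers for stronger inhibition: compound 2 gives > 200000 nM, a limit rather than a number. Compound 3 `Cc1cc(O)cc(O)c1C(=O)O[C@H]1C2=COC(/C=C/CO)=CC2=CC(=O)[C@@]1(C)O` likewise gives only a limit in this assay, > 200000 nM. Among the measured compounds shown here, compound 1 `Cc1cc(O)cc(O)c1C(=O)O[C@H]1[C@@H]2COC(/C=C/C=O)=CC2=CC(=O)[C@@]1(C)O` gives 22900 nM, the one firm number in the set. Compound 4 `Cc1cc(O)cc(O)c1C(=O)O[C@H]1[C@@H]2COC(/C=C/CO)=CC2=CC(=O)[C@@]1(C)O` is not yet measured; it differs from compound 2 by 3-hydroxyprop-1-en-1-yl in place of methoxycarbonyl on a double-bonded ring carbon. For the measured compounds named here, the one step that bears on it is an at least 8.7-fold higher number from compound 1 to compound 2 (0.94 log units; beyond the scatter), which ran the other way and ended at the limit of > 200000 nM in this assay, at which 2 of the 3 values shown sit. Replacing methoxycarbonyl with 3-hydroxyprop-1-en-1-yl is therefore expected to lower the number for compound 4, though compound 3, carrying the same 3-hydroxyprop-1-en-1-yl on a different core, still sits at its limit. Compound 4 is expected near 80000 nM, between 20000 nM and 300000 nM. That amounts to an expected step of an at least 2.5-fold lower number from compound 2 to compound 4 (0.39 log units; beyond the scatter).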

Compound 4, half-maximal inhibitory concentration: > 200000 nM
Compound 4: no number, only a limit (the forecaster's own chance of this, stated with the estimate: 35%); middle value at least 2.5-fold (0.39 log units) from the limit.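

In this assay, keeping the chain on the double-bonded ring carbon does not suffice: hydroxymethyl in place of formyl on the chain gives an at least 8.7-fold higher number from compound 1 to compound 4 (0.94 log units; beyond the scatter). The step between compound 2 and compound 4 cannot be read, as both values are limits. Among these compounds, only compound 1 stays clear of the limit: the limit of > 200000 nM in this assay, at which 3 of the 4 values shown sit.

From the compounds shown here alone, how far compound 2 and compound 4 lie past the limit stays open. Also open, going by these compounds, is whether a carboxylic acid or an amine in place of formyl on the chain would give a firm number.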